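The source may hold more compounds than are shown below. What is called first, only, known or untested is meant among the compounds shown, and "the series" means these compounds.

Measured so far in an assay on isolated protein for displacement of a labelled ligand from melanin-concentrating hormone receptor 1 (Homo sapiens); on this read-out lower numbers stand for stronger inhibition and higher numbers for weaker inhibition:
compound 1, `CN(c1ccc2cc(NC(=O)CCc3ccc(C(F)(F)F)cc3)ccc2n1)C1CCCCC1`, 18 nM
compound 2, `O=C(CCc1ccc(C(F)(F)F)cc1)Nc1ccc2nc(N3CC4CC3CN4)ccc2c1`, 210 nM
compound 3, `Nc1ccc2cc(NC(=O)CCc3ccc(C(F)(F)F)cc3)ccc2n1`, 240 nM

Compound 3 gives the highest of the three numbers in this assay; compound 2 stands nearest, a 1.1-fold higher number from compound 2 to compound 3 (0.06 log units; within the scatter), and compound 1 furthest, a 13-fold higher number from compound 1 to compound 3 (1.12 log units; beyond the scatter). Within the data shown here, compound 4 is `CCCN(CCC)c1ccc2cc(NC(=O)CCc3ccc(C(F)(F)F)cc3)ccc2n1`. dipropylamino in place of amino on an aromatic carbon The step that bears on this change is the one between compound 1 and compound 3, where cyclohexyl(methyl)amino in place of amino corresponds to a large drop in the number; dipropylamino is likewise a group of six carbon and one nitrogen on the same aromatic carbon. The step of a 12-fold higher number from compound 1 to compound 2 (1.07 log units; beyond the scatter) shows that a different group at that position does not bring the same gain. Compound 4 is therefore expected to show a large step down, an 8.0-fold lower number from compound 3 to compound 4 (0.90 log units; beyond the scatter). Compound 4 is estimated at 30 nM, with a range from 10 nM to 100 nM.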

Compound 4, half-maximal inhibitory concentration: 490 nM
The estimate for compound 4 lay 16-fold (1.21 log units) below the measured number; measured number above the stated range.
By their numbers in this assay, from the lowest: compound 1; then compounds 2 and 3 (each within the scatter of the next); then compound 4.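

Dipropylamino in place of amino gives only a small change (a 2.0-fold higher number from compound 3 to compound 4 (0.31 log units; beyond the scatter)), so the low number of compound 1 does not carry over to every dialkylamino group on this aromatic carbon. Against cyclohexyl(methyl)amino the step is large (a 27-fold higher number from compound 1 to compound 4 (1.43 log units; beyond the scatter)), and against the two-ring group it is modest (a 2.3-fold higher number from compound 2 to compound 4 (0.37 log units; beyond the scatter)). No measurement here accounts for these differences.

As far as these compounds go, it remains open which part of cyclohexyl(methyl)amino goes with the low number. Methyl(propyl)amino and cyclohexylamino would separate the methyl from the cyclohexyl ring.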